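This account rests on a few compounds, and the source may have more. Where it says the series, first, only, none or still open, it means among the compounds named here.

Going by the values given here, compound 2 `CCc1ccc(NS(=O)(=O)c2ccc(N3CCNC3=O)cc2)cc1` is the only member of the series with a number in a functional assay on HT-29 cells (Homo sapiens) for antiproliferative activity, read by sulforhodamine B assay, with a stated time of 48 h (a lower number here means a stronger inhibitor, a higher number a weaker inhibitor), where compound 2 gives 660 nM. Compound 1 `O=C1NCCN1c1ccc(S(=O)(=O)Nc2ccc(C3CCCCC3)cc2)cc1` returns only a limit in this assay, > 1000 nM. Compound 3 `CCCCCCOc1ccc(NS(=O)(=O)c2ccc(N3CCNC3=O)cc2)cc1` likewise returns only a limit, > 1000 nM. Both limits sit at the limit of > 1000 nM in this assay, at which 2 of the 3 values shown sit. Among the compounds with values here, the step of an at least 1.5-fold lower number from compound 1 to compound 2 (0.18 log units; that floor lies within the scatter) and the step of an at least 1.5-fold higher number from compound 2 to compound 3 (0.18 log units; that floor lies within the scatter) both change the same aromatic carbon and leave compound 2 as the single readable value. Compound 4 `Cc1ccccc1NS(=O)(=O)c1ccc(N2CCNC2=O)cc1` differs from compound 2 by 2-methylphenyl in place of 4-ethylphenyl on a sulfonamide nitrogen. Within the data shown here, no measured step touches a 2-methylphenyl group, so the two measured steps only show that changes on this aryl move the number toward the limit. For compound 4 the expected step is a 2.3-fold higher number from compound 2 to compound 4 (0.36 log units; beyond the scatter). Compound 4 is estimated at 1500 nM, between 500 nM and 5000 nM.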

Compound 4, half-maximal inhibitory concentration: 200 nM
For compound 4 the middle estimate is 7.5-fold (0.88 log units) above the measured one; measured number below the stated range.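

Going by these compounds alone, replacing 4-ethylphenyl with 2-methylphenyl on the sulfonamide nitrogen gives a 3.3-fold lower number from compound 2 to compound 4 (0.52 log units; beyond the scatter) in this assay, the first step with a number at both ends. Changes on this aryl group therefore do not only lead toward the limit, which remains a limit and not a number: the limit of > 1000 nM in this assay, at which 2 of the 4 values shown sit.

The step changes both the alkyl group and its place on the ring, so the two effects stay unseparated. On these data alone, a 4-methylphenyl or 2-ethylphenyl group would separate them, and an amine or a carboxylic acid on this ring remains open.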